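Cytotoxicity notes on a hydroxypyridazinone series: compound 3 to compound 4

This account rests on a few compounds, and the source may have more. Where it says the series, first, only, none or still open, it means among the compounds named here.

Three members of the series have been tested in an ADME assay on Huh-7 cells (Homo sapiens) for cytotoxicity, with a stated time of 72 h; on this read-out lower numbers stand for higher toxicity in this test and higher numbers for lower toxicity in this test. Compound 1 `CC(C)CCn1nc(-c2cccs2)c(O)c(C2=NS(=O)(=O)c3cc(CS(C)(=O)=O)ccc3N2)c1=O` reaches only a limit, > 33000 nM, in this assay. Compound 2 `CC(C)CCn1nc(CC2=CCCC2)c(O)c(C2=NS(=O)(=O)c3cc(NS(C)(=O)=O)ccc3N2)c1=O` likewise gives only a limit, > 33000 nM. Compound 3 `COCCn1nc(-c2cccs2)c(O)c(C2=NS(=O)(=O)c3cc(NS(C)(=O)=O)ccc3N2)c1=O` stops at a lower limit, > 1000 nM, so no number is known for it and it cannot be placed against the other two beyond the fact that all three sit at limits; the evidence is the limit of > 1000 nM in this assay, at which 1 of the 3 values shown sits, and (the limit of > 33000 nM in this assay, at which 2 of the 3 values shown sit). Among the compounds with values here, no pair of measured compounds differs in a single place, so no measured step is available.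

Compound 4 `CS(=O)(=O)Nc1ccc2c(c1)S(=O)(=O)N=C(c1c(O)c(-c3cccs3)nn(CCC3CCCC3)c1=O)N2` is yet to be measured in this assay. It differs from compound 3 by cyclopentyl in place of methoxy on a saturated chain carbon, two bonds along the chain from an aromatic nitrogen. Compound 1 carries an isopentyl chain in the corresponding position and sits at the higher limit, which is the only hint on what a larger hydrocarbon chain does here. For the step from compound 3 to compound 4 the expectation is no change beyond the scatter, with the result most likely again reported as a limit, a step that the limit leaves unreadable from compound 3 to compound 4. Compound 4 is estimated at 50000 nM, within 10000 nM to 200000 nM.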

Compound 4, half-maximal cytotoxic concentration: > 1000 nM
Compound 4: no number, only a limit; the forecaster's own chance of this, stated with the estimate: 85%; the middle value does not contradict the limit.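

Within the data shown here, compound 3 and compound 4 both stand only at limits in this assay, so no step between them can be read. The compounds shown leave open whether going from 2-methoxyethyl to 2-cyclopentylethyl changes the half-maximal cytotoxic concentration at all, and at what concentration any of these compounds would give a number rather than a limit.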